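Notes on the step from compound 3 to compound 4

The source may report more compounds than this note shows. Statements on the series, on what has been measured and on what is new or still open speak of the compounds shown alone.

The series is read in a functional assay on MCF7 cells (Homo sapiens) for inhibition, read by MTT assay, with a stated time of 72 h; on this read-out lower numbers stand for stronger inhibition and higher numbers for weaker inhibition. Compound 1 `COc1cc(OC)c(-c2cc(=O)c3ccc(O)cc3o2)cc1OC` gives > 150000 nM (a limit of the assay, not a number). Compound 3 `COc1cc(OC)c(OC)cc1/C=C/C(=O)c1ccc(-c2c[nH]cn2)cc1` gives > 150000 nM (again a limit, not a number). Compound 3 therefore stands on the limit of > 150000 nM in this assay, at which 2 of the 3 values shown sit, and has no exact position. Compound 2 `COc1cc(OC)c(OC)cc1/C=C/C(=O)c1cc(Cc2ccccc2)cc(Cc2ccccc2)c1` shares the core of compound 3. Compound 2 gives a true number (23300 nM).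

Compound 4 `COc1cc(OC)c(OC)cc1/C=C/C(=O)c1ccc(F)cc1` differs from compound 3 by fluoro in place of 1H-imidazol-4-yl on an aromatic carbon (fluoro in place of 1H-imidazol-4-yl on an aromatic carbon of a six-membered aromatic ring of carbon only). For the measured compounds named here, no measured pair isolates this change, so the expectation is loose. A move toward lower numbers, beyond the scatter but of modest size, is expected, resting on compound 2 (23300 nM). The expected change is an at least 3.0-fold lower number from compound 3 to compound 4 (0.47 log units; beyond the scatter) (an estimate against a limit). A further limit reading remains possible. Compound 4 is estimated at 50000 nM (expected range 15000 nM to 120000 nM).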

Compound 4, half-maximal inhibitory concentration: 30000 nM
Estimate against measurement, compound 4: 1.7-fold (0.22 log units) above; the measured number falls inside the stated range.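

The position now gives a readable result: in this assay, fluoro in place of 1H-imidazol-4-yl on an aromatic carbon gives an at least 5.0-fold lower number from compound 3 to compound 4 (0.69 log units; beyond the scatter), the only step in the series shown that can be read. Compound 4 shows that the shared core can give a true number without the 1H-imidazol-4-yl ring at this place, with fluoro there instead. The size of the step remains open-ended because compound 3 sits on a limit of the assay rather than on a number: the limit of > 150000 nM in this assay, at which 2 of the 4 values shown sit.

For the compounds shown here, the single step does not separate the loss of the 1H-imidazol-4-yl ring from the arrival of fluoro. Going by these compounds, whether an amine, a carboxylic acid or a longer chain at this position would read closer to fluoro or to 1H-imidazol-4-yl remains open.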